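Swapping an aryl group on a shared triazole-oxadiazole scaffold

The source may hold more compounds than are shown below. What is called first, only, known or untested is meant among the compounds shown, and "the series" means these compounds.

Measured so far:
compound 1 `CC(C)(C)Cn1nnc2c1CCC(c1nc(-c3ccc(F)cc3)no1)C2`: 108%
compound 2 `Cc1ccc(-c2noc(C3CCc4c(nnn4C(C)(C)C)C3)n2)cn1`: 67%

Compound 1 `CC(C)(C)Cn1nnc2c1CCC(c1nc(-c3ccc(F)cc3)no1)C2` and compound 2 `Cc1ccc(-c2noc(C3CCc4c(nnn4C(C)(C)C)C3)n2)cn1` share the same core and differ only in the aryl group on the five-membered ring. In a functional assay on U2OS cells with metabotropic glutamate receptor 5 (Homo sapiens) as the target, read by calcium flux (on this read-out lower numbers stand for smaller maximal responses and higher numbers for larger maximal responses), compound 1 reaches 108%, while compound 2 reaches 67%, the lower of the two numbers, with compound 1 standing above it by a margin beyond the usual scatter.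

Compound 3 `CN(C)c1ccc(-c2noc(C3CCc4c(nnn4C(C)(C)C)C3)n2)cc1` has not yet been measured. It keeps the core of compound 2 and changes the aryl group: 4-(dimethylamino)phenyl in place of 6-methylpyridin-3-yl on an aromatic carbon.

For the measured compounds named here, no measured pair shows this particular change, so its effect cannot be read directly. Going by the values given here, the only comparison available is that compound 1, carrying a phenyl bearing a single substituent, gave a larger maximal response than compound 2. On that basis the step of a number 18 percentage points higher from compound 2 to compound 3 (beyond the scatter) is expected to be upward and moderate, possibly beyond the scatter. For compound 3 the maximal response in this assay is estimated at 85%, within a range from 55% to 115%.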

Compound 3, largest response reached (reported as percent of maximum), in percent of the reference or control that the assay uses: 68%
Compound 3: the middle estimate sits 17 percentage points above what was measured; low and high end bracket the measured number.
By their numbers in this assay, from the lowest: compounds 2 and 3 (each within the scatter of the next); then compound 1.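

In this assay, replacing 6-methylpyridin-3-yl with 4-(dimethylamino)phenyl on this aromatic carbon gives a number 1 percentage points higher from compound 2 to compound 3 (within the scatter). For the compounds shown here, this is the first direct comparison at this position, and on this read-out it does not separate the two aryl groups, although one has a ring of carbon only and the other a ring with a hetero atom. The data shown offer no explanation for this result.

Going by these compounds alone, compound 1 differs from compound 2 and compound 3 in more than one place, so no step to it can be read. Going by these compounds, it remains open how a 4-methoxyphenyl or 4-cyanophenyl group would behave at this position on the same core, and whether a 4-fluorophenyl group there would give a maximal response outside the scatter of compound 2 and compound 3.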